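One Ring Swap on a Carbonyl Carbon

The source may hold more compounds than are shown below. What is called first, only, known or untested is meant among the compounds shown, and "the series" means these compounds.

Measured so far:
compound 1 `N=C(N)N/N=C/c1ccc(/C=C/C(=O)c2ccc(Br)cc2)cc1`: 68.9%
compound 2 `O=C(N/N=C/c1ccc(/C=C/C(=O)c2ccccc2Cl)cc1)c1cccc(Cl)c1`: 43%

Of the compounds shown here, two have been tested in a functional assay on the whole organism (Ear) for inhibition, with Mus musculus as the target, with a stated time of 30 min, at a dose of 100 mg/kg by the intraperitoneal route; a higher number here means more inhibition at the dose given (going by the name of the read-out), a lower number less inhibition. Compound 1 stands highest of the two, giving 68.9%. Compound 2 is the nearest, and in this assay compound 2 gives 43%, a gap beyond the usual scatter. These two differ in more than one place, so nothing more than their two values can be read from them.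

Compound 3 `N=C(N)N/N=C/c1ccc(/C=C/C(=O)c2ccccc2F)cc1` has not yet been measured. It is reached from compound 1 by a single change: 2-fluorophenyl in place of 4-bromophenyl on a carbonyl carbon. Within the data shown here, no pair of measured compounds differing in one place is available, so the size of this step cannot be taken from anything already observed.

The expectation rests on compound 1 alone, whose 68.9% sets the starting point. A step of modest size is expected, most likely downward but possibly no larger than the scatter. Compound 3 is expected to give an estimate of 55%, ranging from 35% to 75%. This estimate means an expected step of a number 13.9 percentage points lower from compound 1 to compound 3 (beyond the scatter).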

Compound 3, a percentage reported as inhibition, in the whole organism at one dose (the size of the read-out at that dose, not a potency): 91.7%
Compound 3: the middle estimate sits 36.7 percentage points below what was measured; measured number above the stated range.
By their numbers in this assay, from the lowest: compound 2; then compound 1; then compound 3.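

In this assay, among these compounds, putting 2-fluorophenyl in place of 4-bromophenyl on a carbonyl carbon gives the only step that can be read so far, a number 22.8 percentage points higher from compound 1 to compound 3 (beyond the scatter). This shows that the group at this position matters to the read-out, even though the two groups match in every count given: the same number of heavy atoms, one six-membered aromatic ring of carbon only, no hydrogen-bond donors or acceptors, and no net charge. What they differ in is the halogen and where it is numbered on the ring, and nothing available bears on why this swap raises the number.

Because the halogen and its numbered location change together in this single step, the compounds shown cannot separate the two, and groups such as plain phenyl, 4-fluorophenyl or 2-bromophenyl on the carbonyl carbon would be needed to do so. They also leave open whether a ring carrying a methoxy group or an amine would hold this level, and whether the same swap would have a similar effect on the core of compound 2.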